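This account rests on a few compounds, and the source may have more. Where it says the series, first, only, none or still open, it means among the compounds named here.

Measured so far:
compound 1 `Cc1cc2nccc(-c3cc(Cl)cc4c3O[C@@H](C(=O)N3CCNCC3)C4)c2s1` — > 80000 nM
compound 2 `O=C(C1Cc2cc(Cl)cc(-c3ccnc4[nH]ccc34)c2O1)N1CCNCC1` — > 80000 nM

In an assay on Sf21 cells for inhibition of ubiquitin carboxyl-terminal hydrolase 1 (Homo sapiens), read by fluorescence (on this read-out higher numbers stand for weaker inhibition and lower numbers for stronger inhibition), compound 1 gives > 80000 nM, which is a limit of the assay and not a number. In this assay compound 2 gives > 80000 nM, likewise a limit. Among the measured compounds shown here, compound 1 thus stands at the limit of > 80000 nM in this assay, at which 2 of the 2 values shown sit, so no measured step exists. Compound 3 `O=C([C@H]1Cc2cc(Cl)cc(-c3ccnc4cc(CO)sc34)c2O1)N1CCNCC1` is not yet measured; it differs from compound 1 by hydroxy in place of hydrogen on a saturated chain carbon bound to an aromatic carbon. With both measured values at the limit, no step beyond the scatter is expected in this assay in either direction, and another limit is the likeliest outcome. For compound 3 the estimate is 80000 nM, ranging 20000 nM to 300000 nM, which as a step means a number no higher from compound 1 to compound 3 (the limit leaves the size open).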

Compound 3, half-maximal inhibitory concentration: > 40000 nM
Compound 3: no number, only a limit; the forecaster's own chance of this, stated with the estimate: 85%; the middle value is on the limit's open side.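

In this assay, among the compounds shown here, compound 1 and compound 3 both stand at limits of the assay, so no step between them can be read. The compounds shown leave open whether methyl to hydroxymethyl changes inhibition at all.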